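Replacing azido with fluoro in compound 1

The compounds below may be only part of what the source reports. "The series", "measured", "known", "first", "only" and "open" are said of these compounds alone.

Compound 1 `Cc1cn([C@@H]2O[C@H](CO)[C@@H](CN=[N+]=[N-])[C@@H]2O)c(=O)[nH]c1=O`: > 100 uM
Compound 2 `Cc1cn([C@@H]2O[C@H](CO)[C@@H](CN)[C@H]2O)c(=O)[nH]c1=O`: > 100 uM
Compound 3 `Cc1cn([C@@H]2O[C@H](CO)[C@@H](CO)[C@H]2O)c(=O)[nH]c1=O`: > 100 uM

In a functional assay on P388 cells (Mus musculus) for antiproliferative activity, with a stated time of 72 h (a lower number here means that less compound is needed, a higher number that more compound is needed for the effect), compound 1 gives > 100 uM, which is a limit and not a number. The other two measured compounds share that position: the limit of > 100 uM in this assay, at which 3 of the 3 values shown sit.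

Compound 4 `Cc1cn([C@@H]2O[C@H](CO)[C@@H](CF)[C@@H]2O)c(=O)[nH]c1=O` carries fluoro in place of the azido group of compound 1: fluoro in place of azido on a saturated chain carbon bound to a saturated ring carbon.

Within the data shown here, only one measured step changes a group at this kind of place, a step that the two limits leave unreadable from compound 2 to compound 3, so it gives no size to carry over. Among the measured compounds shown here, no measured compound has yet given a number in this assay, so no step beyond the scatter is expected. The expected step is a step that the limit leaves unreadable from compound 1 to compound 4. Compound 4 is estimated at 150 uM, with an expected range of 60 uM to 400 uM.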

Compound 4, concentration for half-maximal effect: > 100 uM
Compound 4 was reported as a limit; the forecaster's own chance of this, stated with the estimate: 85%; the middle value is on the limit's open side.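

Compound 1 and compound 4 both stand only at a limit in this assay, and the step between them cannot be read. The compounds shown leave open how azido and fluoro truly compare in this assay, and what actual number any of these compounds would give.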